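Moving the Chlorine on the Urea Aryl Ring

A few compounds are considered here, and "the series" means these few. Any claim that something is new, unique, unknown or untested is made for them only; others in the source may bear on it.

Compound 1 `CN(C)CCNc1nc(-c2ccc(NC(=O)Nc3ccc(Cl)cc3)cc2)nc2ccsc12` carries a urea capped by a 4-chlorophenyl group. In a functional assay on MKN-45 cells (Homo sapiens) for cytotoxicity, read by MTT assay, with a stated time of 72 h (a higher number here means a weaker inhibitor, a lower number a stronger inhibitor), compound 1 gives 250 nM. Compound 3 `CN(C)CCNc1nc(-c2ccc(NC(=O)Nc3ccccc3Cl)cc2)nc2ccsc12` keeps the core of compound 1 and differs only by 2-chlorophenyl in place of 4-chlorophenyl on an amide-type nitrogen. In this assay compound 3 gives 850 nM, so this change produced a step of a 3.4-fold higher number from compound 1 to compound 3 (0.53 log units; beyond the scatter).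

Compound 2 `CN(C)CCNc1nc(-c2ccc(NC(=O)Nc3ccc(Cl)cc3)cc2)nc2c(Cl)c(Cl)sc12` keeps the urea end of compound 1 on a different core; the difference between the two cores is not broken down here. In this assay compound 2 gives 910 nM, a higher number than compound 1 shows, while compound 2 and compound 3 lie within the scatter of each other.

Compound 4 `CN(C)CCNc1nc(-c2ccc(NC(=O)Nc3ccccc3Cl)cc2)nc2c(Cl)c(Cl)sc12` stands to compound 2 as compound 3 stands to compound 1: it differs by 2-chlorophenyl in place of 4-chlorophenyl on an amide-type nitrogen, at a place described in the same words, on an amide-type nitrogen whose other neighbours are a carbonyl carbon. This is the same change, seen once before in the pair already measured. Among the compounds with values here, the expectation for compound 4 rests on that single precedent, since no second example is available to show whether the core of compound 2 alters the outcome. The step from compound 2 to compound 4 in this assay is expected to be a 3.1-fold higher number from compound 2 to compound 4 (0.49 log units; beyond the scatter), because the earlier step was a 3.4-fold higher number from compound 1 to compound 3 (0.53 log units; beyond the scatter). Compound 4 is therefore estimated at 2800 nM, with a likely range from 1200 nM to 7000 nM.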

Compound 4, half-maximal inhibitory concentration: 1170 nM
Compound 4: middle estimate off by 2.4-fold (0.38 log units), on the high side; the measured number lies below the stated range.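

On the core of compound 2, placing 2-chlorophenyl where 4-chlorophenyl stood on the amide-type nitrogen gives a 1.3-fold higher number from compound 2 to compound 4 (0.11 log units; within the scatter) in this assay, so on this core the change does not stand out from the scatter of repeated measurements. Set beside the earlier step, the new one gives no ground for saying that the core alters the outcome of this change: the same change on two cores in this assay, a 3.4-fold higher number (0.53 log units; beyond the scatter) from compound 1 to compound 3 and a 1.3-fold higher number (0.11 log units; within the scatter) from compound 2 to compound 4, 2.6-fold (0.42 log units) apart, within the scatter of two such steps. Within the data shown here, this does not show that the change carries over from one core to the other at a fixed size, since the comparison rests on only two pairs and only the step on the core of compound 1 lies beyond the scatter.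

The compounds shown leave open whether the two steps would stay together if a bromine, a methoxy group or a nitrile took the place of the chlorine on the urea aryl ring. They also leave open whether the same comparison would hold with a longer chain in place of the dimethylaminoethyl chain, which all four compounds share.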